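The source may report more compounds than this note shows. Statements on the series, on what has been measured and on what is new or still open speak of the compounds shown alone.

Compound 1 `O=C(C1CC1)N1CCN(Cc2nc3ccccc3n2Cc2ccccc2C(F)(F)F)CC1` stands highest of the three compounds measured in an assay on isolated protein for inhibition of aldehyde dehydrogenase 1A1 (Homo sapiens), read by spectrophotometry, tested at 10 uM (on this read-out lower numbers stand for less inhibition and higher numbers for more inhibition at the one concentration tested (going by the name of the read-out)), where compound 1 gives 56.3%. Compound 2 `Cc1cccc(Cn2c(CN3CCN(C(=O)c4ccc(C(F)(F)F)cc4)CC3)nc3ccccc32)c1` gives 22.9% and compound 3 `Cc1cccc(Cn2c(CN3CCN(C(=O)c4cccnc4)CC3)nc3ccccc32)c1` gives 24.5%; both differ from compound 1 at two places, so the gaps from compound 1 to them cannot be assigned to one change. For the measured compounds named here, the one single-point step measured, a number 1.6 percentage points higher from compound 2 to compound 3 (within the scatter), concerns the group on the carbonyl carbon and not the place altered here.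

Compound 4 `O=C(C1CC1)N1CCN(Cc2nc3ccccc3n2Cc2cccc(Cl)c2)CC1` carries the change (3-chlorophenyl in place of 2-(trifluoromethyl)phenyl on a saturated chain carbon bound to an aromatic nitrogen). Going by the values given here, no measured step bears directly on it; the only comparison that touches the same place is the fall from compound 1 to compounds 2 and 3, which is confounded by the carbonyl substituent. The expectation is therefore a loss from compound 1 of uncertain size, a number 16.3 percentage points lower from compound 1 to compound 4 (beyond the scatter), with a wide range. Compound 4 is estimated to give 40% in this assay, between 15% and 62%.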

Compound 4, a percentage reported as inhibition, at one concentration (the size of the read-out at that concentration, not a potency): 71.6%
The estimate for compound 4 lay 31.6 percentage points below the measured number; measured number above the stated range.
By their numbers in this assay, from the lowest: compounds 2 and 3 (each within the scatter of the next); then compound 1; then compound 4.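

In this assay, 3-chlorophenyl in place of 2-(trifluoromethyl)phenyl on a saturated chain carbon bound to an aromatic nitrogen gives a number 15.3 percentage points higher from compound 1 to compound 4 (beyond the scatter) with the rest of compound 1 unchanged. For the compounds shown here, this is the first reading at this place free of any change at the carbonyl, and it shows that inhibition at the one concentration tested does not depend on keeping 2-(trifluoromethyl)phenyl, even though the entering group has fewer heavy atoms than the group it replaces. Nothing measured on these compounds accounts for the rise.

Still open, going by these compounds, is whether the gain follows the arrival of chlorine or the departure of trifluoromethyl, as the two change together; an unsubstituted phenyl at the same place would help separate them. Also open, on these data alone, is whether 3-chlorophenyl keeps its gain with pyridin-3-yl on the carbonyl carbon.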